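Swapping Methyl for 4-Fluorophenyl on an Aromatic Nitrogen

The source may hold more compounds than are shown below. What is called first, only, known or untested is meant among the compounds shown, and "the series" means these compounds.

Compound 1 `Cn1nc(C(C)(C)C)cc1NC(=O)Nc1cc(C(F)(F)F)cc(C(F)(F)F)c1` gives 1.1 degrees C in an assay on isolated protein for inhibition of serine/threonine-protein kinase 10 (Homo sapiens), read by thermal shift assay, tested at 10 uM; a higher number here means that the compound stabilises the target more against heat, a lower number that the compound stabilises the target less.
Compound 2 `CC(C)(C)c1cc(NC(=O)Nc2cc(C(F)(F)F)cc(C(F)(F)F)c2)n(-c2ccc(F)cc2)n1` gives -0.6 degrees C in this assay.
Compound 3 `Cn1nc(C(C)(C)C)cc1NC(=O)Nc1cc(F)cc(F)c1` gives 1.1 degrees C in this assay.

Among the compounds with values here, the one measured step in this small set is a number 1.7 degrees C lower from compound 1 to compound 2 (beyond the scatter), produced by the change (4-fluorophenyl in place of methyl on an aromatic nitrogen). Compound 3 stands level with compound 1, the two highest numbers of the three, and the difference between the cores of compound 1 and compound 3 is not broken down here.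

Compound 4 `CC(C)(C)c1cc(NC(=O)Nc2cc(F)cc(F)c2)n(-c2ccc(F)cc2)n1` carries the change 4-fluorophenyl in place of methyl on an aromatic nitrogen relative to compound 3. The place of the change is described in the same words as for compound 1 to compound 2, so this is the same change, made on the core of compound 3 instead. Within the data shown here, with only a single measured step of this kind to rest on, the expectation is that the step from compound 3 to compound 4 will be of about the same size as the step from compound 1 to compound 2, because a number 1.7 degrees C lower from compound 1 to compound 2 (beyond the scatter). Compound 4 is therefore expected to give -0.6 degrees C in this assay, with an estimated range from -2 degrees C to 0.8 degrees C. This estimate means a step of a number 1.7 degrees C lower from compound 3 to compound 4 (beyond the scatter).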

Compound 4, shift of the target's melting temperature: 1.7 degrees C
Compound 4: middle estimate off by 2.3 degrees C, on the low side; the measured number lies above the stated range.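

In this assay, the change of 4-fluorophenyl in place of methyl on an aromatic nitrogen did not carry over unchanged from one core to the other: the same change on two cores in this assay, a number 1.7 degrees C lower (beyond the scatter) from compound 1 to compound 2 and a number 0.60 degrees C higher (within the scatter) from compound 3 to compound 4, 2.3 degrees C apart, beyond the scatter of two such steps

On the core of compound 3 the result is a number 0.60 degrees C higher from compound 3 to compound 4 (within the scatter), so on this core the swap gives no difference that can be told apart from repeat measurement, and the drop seen on the core of compound 1 is not a general result of the change. Within the data shown here, with only two pairs, the account cannot say which feature of the two cores sets the outcome, and it cannot say how the same change would read on a third core.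

As far as these compounds go, all four compounds keep the tert-butyl group and carry only methyl or 4-fluorophenyl on the aromatic nitrogen, so it remains open how a longer chain or a chain ending in an amine would read at that nitrogen. From the compounds shown here alone, it also remains open whether a carboxylic acid or a nitrile in place of the tert-butyl group would alter the outcome of this change.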